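Cyclic peptide series: aromatic side chain at one position

The compounds below may be only part of what the source reports. "The series", "measured", "known", "first", "only" and "open" are said of these compounds alone.

Measured: compound 1 `N=C(N)NCCC[C@@H]1NC(=O)CNC(=O)C[C@@H](C(=O)O)NC(=O)[C@@H](c2ccccc2)NC(=O)[C@H](CCCCN)NC1=O` gives 94 nM in an assay on a protein complex for binding affinity to integrin alpha-5/beta-1 (Homo sapiens), read by ELISA; a lower number here means a stronger inhibitor, a higher number a weaker inhibitor; compound 2 `N=C(N)NCCC[C@@H]1NC(=O)CNC(=O)C[C@@H](C(=O)O)NC(=O)[C@@H](c2ccccc2)NC(=O)[C@H](Cc2ccc(O)cc2)NC1=O` gives 39 nM in this assay.

Among the compounds with values here, compound 2 holds the lower of the two numbers so far, the step of a 2.4-fold lower number from compound 1 to compound 2 (0.38 log units; beyond the scatter) lying beyond the scatter. Compound 3 `N=C(N)NCCC[C@@H]1NC(=O)CNC(=O)C[C@@H](C(=O)O)NC(=O)[C@@H](c2ccccc2)NC(=O)[C@H](Cc2c[nH]c3ccccc23)NC1=O` carries 1H-indol-3-yl in place of 4-hydroxyphenyl on a saturated chain carbon bound to a saturated ring carbon. Within the data shown here, no measured step exchanges one aromatic group for another at this place; only the step from compound 1 to compound 2 touches it, and it was modest. The expected step of a 1.1-fold lower number from compound 2 to compound 3 (0.05 log units; within the scatter) in this assay is therefore small, direction uncertain. Compound 3 is estimated at 35 nM, range 12 nM to 100 nM.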

Compound 3, half-maximal inhibitory concentration: 72 nM
Estimate against measurement, compound 3: 2.1-fold (0.31 log units) below; the measured number falls inside the stated range.
By their numbers in this assay, from the lowest: compounds 2, 3 and 1 (each within the scatter of the next, the first and the last beyond it).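

In this assay, 1H-indol-3-yl in place of 4-hydroxyphenyl gives a 1.8-fold higher number from compound 2 to compound 3 (0.27 log units; within the scatter) so these two aromatic groups are not told apart at this place. 1H-indol-3-yl in place of 3-aminopropyl gives a 1.3-fold lower number from compound 1 to compound 3 (0.12 log units; within the scatter) so, of the two aromatic groups, only 4-hydroxyphenyl stands clear of the scatter against 3-aminopropyl. No evidence is available to account for these numbers.

Open, on these data alone, is whether the hydroxyl of 4-hydroxyphenyl contributes to the step from 3-aminopropyl, which a plain phenyl at this place would test. Also open, as far as these compounds go, is how a chain ending in a carboxylic acid would compare with 3-aminopropyl.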